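Indole substitution on a shared core: trifluoromethyl step

The source may hold more compounds than are shown below. What is called first, only, known or untested is meant among the compounds shown, and "the series" means these compounds.

Compound 3 `COC(=O)[C@@]1(C)CCC=C2[C@@H]1CC[C@@H](C)[C@]2(C)Cc1c(C)[nH]c2ccc(C)cc12` gives 17000 nM in a functional assay on HeLa cells (Homo sapiens) for inhibition, read by sulforhodamine B assay, with a stated time of 48 h; a lower number here means a stronger inhibitor of growth, a higher number a weaker inhibitor of growth. Compound 1 `COC(=O)[C@@]1(C)CCC=C2[C@@H]1CC[C@@H](C)[C@]2(C)Cc1c[nH]c2ccc(C)cc12` gives 14000 nM and compound 2 `COC(=O)[C@@]1(C)CCC=C2[C@@H]1CC[C@@H](C)[C@]2(C)Cc1c[nH]c2c(Cl)cccc12` gives 14000 nM; all three values lie within the scatter of each other, so compound 3 stands level with its neighbours. Within the data shown here, the one single-change step measured, a 1.2-fold higher number from compound 1 to compound 3 (0.08 log units; within the scatter), was within the scatter. Compound 4 `COC(=O)[C@@]1(C)CCC=C2[C@@H]1CC[C@@H](C)[C@]2(C)Cc1c(C)[nH]c2ccc(C(F)(F)F)cc12` differs from compound 3 by trifluoromethyl in place of methyl on an aromatic carbon. Among the measured compounds shown here, no measured step exchanges methyl for trifluoromethyl, so the only guide is the flat picture across compounds 1, 2 and 3; on that basis no change beyond the scatter is expected in this assay. Compound 4 is therefore estimated at 15000 nM, range 6000 nM to 40000 nM, meaning an expected step of a 1.1-fold lower number from compound 3 to compound 4 (0.05 log units; within the scatter).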

Compound 4, concentration for 50% growth inhibition: 12000 nM
Estimate against measurement, compound 4: 1.3-fold (0.10 log units) above; the range from low to high includes it.
By their numbers in this assay, from the lowest: compounds 4, 1, 2 and 3 (each within the scatter of the next).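

Trifluoromethyl in place of methyl on this aromatic carbon gives a 1.4-fold lower number from compound 3 to compound 4 (0.15 log units; within the scatter) in this assay, the first change shown at this position, since compound 1 and compound 3 both carry methyl here. The position therefore accepts a group with more heavy atoms and with fluorine without a step beyond the scatter. No measurement is available that could explain this result.

From the compounds shown here alone, whether any group on this carbon can move the number beyond the scatter remains open. An amine or a carboxylic acid here would test this.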